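Swapping the Distal Substituent of Compound 3

This account rests on a few compounds, and the source may have more. Where it says the series, first, only, none or still open, it means among the compounds named here.

Compound 3 `CC[C@H](C)[C@H](N)CN(C(=O)[C@@H]1C[C@H]1c1ccccc1)c1ccc(-c2ccc(OC(F)(F)F)cc2)cc1` carries the lowest number of the three compounds measured here: in a functional assay for agonist activity at G protein-coupled receptor 88 (Homo sapiens), read by HTRF and cAMP accumulation (a lower number here means that less compound is needed, a higher number that more compound is needed for the effect), compound 3 gives 170 nM. Compound 2 `CC[C@H](C)[C@H](N)CN(C(=O)[C@@H]1C[C@H]1c1ccoc1)c1ccc(-c2ccccc2)cc1` gives 580 nM in this assay, and compound 1 `CC[C@H](C)[C@H](N)CN(C(=O)[C@@H]1C[C@H]1c1cc(F)cc(F)c1)c1ccc(-c2ccccc2)cc1` gives 960 nM; the gaps from compound 3 to both of them lie beyond the scatter, so compound 3 is the most potent of the three. Among the measured compounds shown here, the only step between measured compounds that differ in one place, a 1.7-fold lower number from compound 1 to compound 2 (0.22 log units; within the scatter), concerns the ring attached to the saturated ring carbon, not the distal aromatic ring, and it stays within the scatter.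

Compound 4 `CC[C@H](C)[C@H](N)CN(C(=O)[C@@H]1C[C@H]1c1ccccc1)c1ccc(-c2ccc(NC(C)=O)cc2)cc1` has not yet been measured. It differs from compound 3 in a single place: acetamido in place of trifluoromethoxy on an aromatic carbon. For the measured compounds named here, no measured pair bears on this change; the step from compound 1 to compound 2 touches another part of the molecule and is small. The expectation therefore rests on compound 3 alone and carries a wide range. Compound 4 is expected to give 400 nM in this assay, estimated to fall between 120 nM and 1500 nM, which means an expected step of a 2.4-fold higher number from compound 3 to compound 4 (0.37 log units; beyond the scatter) that may or may not exceed the scatter.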

Compound 4, half-maximal effective concentration: 5500 nM
Estimate against measurement, compound 4: 14-fold (1.14 log units) below; measured number above the stated range.
By their numbers in this assay, from the lowest: compound 3; then compounds 2 and 1 (each within the scatter of the next); then compound 4.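

Among the compounds shown here, the position carrying this substituent, which no earlier pair had touched, proves far from indifferent in this assay: acetamido in place of trifluoromethoxy, on an aromatic carbon para to a large group, gives a 32-fold higher number from compound 3 to compound 4 (1.51 log units; beyond the scatter), a large step. The only earlier step, a 1.7-fold lower number from compound 1 to compound 2 (0.22 log units; within the scatter), concerned the ring on the saturated ring carbon and stayed within the scatter, so this is the first sign that a single change in the compounds shown can move the number this far. The two groups differ in several counted ways at once, with acetamido bringing a hydrogen-bond donor and a double bond outside aromatic rings and trifluoromethoxy bringing three fluorine atoms, and no available evidence explains the size of the step.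

The compounds shown leave open which of these differences matters, since a single pair cannot separate them; a methoxy group, a trifluoromethyl group or a plain amine at this aromatic carbon would each divide the change differently. Also open, from the compounds shown here alone, is whether the same step holds when furan-3-yl or 3,5-difluorophenyl sits on the saturated ring carbon.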